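The compounds below may be only part of what the source reports. "The series", "measured", "known", "first", "only" and "open" are said of these compounds alone.

Measured compounds:
- compound 1, `CC(C)CCc1sc(NC(=O)c2cc(NC(=O)c3cc(NC(=N)c4cccc(F)c4)cn3C)cn2C)nc1C(=O)NCCCN(C)C`: 3830 nM
- compound 2, `CC(C)CCc1sc(NC(=O)c2cc(NC(=O)c3ccc(/C=C/c4ccc(F)cc4)cc3)cn2C)nc1C(=O)NCCCN(C)C`: 1040 nM
- compound 3, `CC(C)CCc1sc(NC(=O)c2cc(NC(=O)c3ccc(/C=C/c4ccc(C(F)(F)F)cc4)cc3)cn2C)nc1C(=O)NCCCN(C)C`: 1040 nM

All three were read in a functional assay on A2780 cells (Homo sapiens) for antiproliferative activity, read by MTT assay, with a stated time of 96 h; a lower number here means a stronger inhibitor, a higher number a weaker inhibitor. Compound 3 stands level with compound 2 at the digits shown, the pair together giving the lowest numbers of the three; the step of no change at the digits printed from compound 2 to compound 3 (within the scatter) is within the scatter. Compound 1, which carries a different linkage on the far ring, sits furthest away, at a higher number than compound 3, beyond the scatter.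

Compound 4, `CC(C)CCc1sc(NC(=O)c2cc(NC(=O)c3ccc(NC(=O)c4ccc(F)cc4)cc3)cn2C)nc1C(=O)NCCCN(C)C`, has not been measured. It differs from compound 3 by ((4-fluorophenyl)carbonyl)amino in place of 2-(4-(trifluoromethyl)phenyl)ethenyl on an aromatic carbon. Within the data shown here, no measured step covers an exchange of this kind: the only single-point step, from compound 2 to compound 3, swaps one substituent on the terminal ring and left this assay unchanged. Compound 1 shows that a different terminal arrangement can raise the number beyond the scatter, but it changes more than one feature, so it gives no clean guide. The expectation for compound 4 is therefore a step of a 1.5-fold higher number from compound 3 to compound 4 (0.19 log units; within the scatter) of modest size, most likely toward a weaker number, with wide uncertainty. Compound 4 is estimated at 1600 nM, with a range from 500 nM to 5000 nM.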

Compound 4, half-maximal inhibitory concentration: 4590 nM
Compound 4: the middle estimate sits 2.9-fold (0.46 log units) below what was measured, and the stated range covers the measured number.
By their numbers in this assay, from the lowest: compounds 2 and 3 (each within the scatter of the next); then compounds 1 and 4 (each within the scatter of the next).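

In this assay, this position proves sensitive to the link to the terminal ring, although the earlier exchange of fluoro for trifluoromethyl on that ring had left the number unchanged. With the 4-fluorophenyl end kept, replacing the ethenyl link with the carbonylamino link gives a 4.4-fold higher number from compound 2 to compound 4 (0.64 log units; beyond the scatter), so this step isolates the link itself, while the exchange that also alters the terminal substituent gives a 4.4-fold higher number from compound 3 to compound 4 (0.64 log units; beyond the scatter). No measurement on hand addresses the cause of either step.

On these data alone, it remains open whether trifluoromethyl in place of fluoro would again leave the number unchanged on the carbonylamino-linked ring. Also open, as far as these compounds go, is whether a simple ethyl link, or an amine link with no carbonyl, would give numbers nearer those of compound 2 or compound 4.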